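The source may hold more compounds than are shown below. What is called first, only, known or untested is meant among the compounds shown, and "the series" means these compounds.

Measured so far in an assay on isolated protein for inhibition of Equilibrative nucleoside transporter 1 (Homo sapiens); a higher number here means a weaker inhibitor, a lower number a stronger inhibitor:
- compound 1 `OC[C@H]1O[C@@H](n2cnc3c(SCc4ccccc4Cl)ncnc32)[C@H](O)[C@@H]1O`: 117 nM
- compound 2 `OC[C@H]1O[C@@H](n2cnc3c(SCc4ccccc4Br)ncnc32)[C@H](O)[C@@H]1O`: 151 nM
- compound 3 `N#Cc1cccc(CSc2ncnc3c2ncn3[C@@H]2O[C@H](CO)[C@@H](O)[C@H]2O)c1`: 36.3 nM

Compound 3 gives the lowest number of the three in this assay; its nearest neighbour is compound 1, a step of a 3.2-fold lower number from compound 1 to compound 3 (0.51 log units; beyond the scatter) away, and compound 2 lies further off, at a 4.2-fold lower number from compound 2 to compound 3 (0.62 log units; beyond the scatter). Between compounds 1 and 2 the step of a 1.3-fold higher number from compound 1 to compound 2 (0.11 log units; within the scatter) is within the scatter.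

Compound 4 `O=[N+]([O-])c1ccccc1CSc1ncnc2c1ncn2[C@@H]1O[C@H](CO)[C@@H](O)[C@H]1O` differs from compound 3 by 2-nitrophenyl in place of 3-cyanophenyl on a saturated chain carbon bound to a sulfur. Within the data shown here, the steps that bear on this change are the two that put a 3-cyanophenyl in place of a 2-halophenyl, a 3.2-fold lower number from compound 1 to compound 3 (0.51 log units; beyond the scatter) and a 4.2-fold lower number from compound 2 to compound 3 (0.62 log units; beyond the scatter), both modest and both toward lower numbers. Going back to a 2-substituted phenyl is therefore expected to reverse that, with a modest rise, a 2.6-fold higher number from compound 3 to compound 4 (0.42 log units; beyond the scatter). Among the measured compounds shown here, no measured step covers a nitro group, so the range is kept wide. Compound 4 is estimated at 95 nM, between 30 nM and 320 nM.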

Compound 4, inhibition constant: 115 nM
Beside the measured number, compound 4's estimate is 1.2-fold (0.08 log units) below it; measured number inside the range.
By their numbers in this assay, from the lowest: compound 3; then compounds 4, 1 and 2 (each within the scatter of the next).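

In this assay, 2-nitrophenyl on the saturated chain carbon bound to a sulfur does not keep the advantage of 3-cyanophenyl: a 3.2-fold higher number from compound 3 to compound 4 (0.50 log units; beyond the scatter). Nitro in place of bromo, a 1.3-fold lower number from compound 2 to compound 4 (0.12 log units; within the scatter), and nitro in place of chloro, a 1.0-fold lower number from compound 1 to compound 4 (0.01 log units; within the scatter), both stay within the scatter, so compounds 1, 2 and 4 cannot be told apart, and only compound 3 stands apart from them. No measurement on hand offers a cause for these results.

On these data alone, whether the lower number of compound 3 goes with the nitrile or with where it sits on the ring stays open. So does what an amine or a carboxylic acid on that phenyl ring would give.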